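The source may hold more compounds than are shown below. What is called first, only, known or untested is meant among the compounds shown, and "the series" means these compounds.

Measured in a functional assay on DU-145 cells (Homo sapiens) for inhibition, read by trypan blue exclusion, with a stated time of 96 h; on this read-out higher numbers stand for weaker inhibition of growth and lower numbers for stronger inhibition of growth:
- compound 1 `O=C(/C(=C\c1ccc(Cl)cc1)S(=O)(=O)c1ccc(Br)cc1)c1ccc(Br)cc1`: 50000 nM
- compound 2 `O=C(/C(=C\c1ccc(F)c([N+](=O)[O-])c1)S(=O)(=O)c1ccc(Br)cc1)c1ccc(Br)cc1`: 25000 nM
- compound 3 `O=C(/C(=C\c1ccc(I)cc1)S(=O)(=O)c1ccc(Br)cc1)c1ccc(Br)cc1`: 1000 nM

Compound 3, at 1000 nM, has the lowest number of the three, so it inhibits growth the most strongly. Both a 50-fold lower number from compound 1 to compound 3 (1.70 log units; beyond the scatter) and a 25-fold lower number from compound 2 to compound 3 (1.40 log units; beyond the scatter) show how far it stands from the others. By contrast, a 2.0-fold lower number from compound 1 to compound 2 (0.30 log units; within the scatter) shows two different groups that cannot be told apart on this read-out.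

Compound 4 `Nc1c(Br)cc(Br)cc1/C=C(\C(=O)c1ccc(Br)cc1)S(=O)(=O)c1ccc(Br)cc1` has not yet been measured. It carries 2-amino-3,5-dibromophenyl in place of 4-iodophenyl on a double-bonded chain carbon bound to a double-bonded chain carbon.

The measured steps all concern the group at this same place. Among these three compounds, the 4-iodophenyl of compound 3 is the only group giving a low number, as a 25-fold lower number from compound 2 to compound 3 (1.40 log units; beyond the scatter) shows, so replacing it is expected to raise the number. Among the compounds with values here, no measured compound carries an amino group on this ring, so the size of the change remains uncertain, and a more modest rise than those large steps seems reasonable.

The expected change is a 6.0-fold higher number from compound 3 to compound 4 (0.78 log units; beyond the scatter). For compound 4 the estimated value is 6000 nM, expected to fall between 1000 nM and 40000 nM.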

Compound 4, concentration for 50% growth inhibition: 25000 nM
The estimate for compound 4 lay 4.2-fold (0.62 log units) below the measured number; low and high end bracket the measured number.
By their numbers in this assay, from the lowest: compound 3; then compounds 2, 4 and 1 (each within the scatter of the next).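

In this assay, the new ring does not keep the low number of the 4-iodophenyl group, with a 25-fold higher number from compound 3 to compound 4 (1.40 log units; beyond the scatter), while it cannot be told apart from the other two rings, with no change at the digits printed from compound 2 to compound 4 (within the scatter) and a 2.0-fold lower number from compound 1 to compound 4 (0.30 log units; within the scatter). This leaves compound 3 alone as the strongest inhibitor of growth among the four, and three quite different rings together at a clearly weaker level, so this position does respond to the ring placed there, but not simply to having a halogen on it: compound 1 carries chloro, compound 2 fluoro and compound 4 bromo, and only the iodo of compound 3 goes with a low number. Nothing shown explains why the iodo compound stands apart.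

Compound 4 differs from compound 3 in several features of the ring at once, so the amino group and the two bromo groups cannot be separated as the source of the rise. A plain 4-bromophenyl at this place would be the closest test of whether iodo itself matters, and the compounds shown give no reading for that group.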